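Pyrrolidin-1-yl in Place of Methylsulfanyl: Cytotoxicity Data

The source may report more compounds than this note shows. Statements on the series, on what has been measured and on what is new or still open speak of the compounds shown alone.

Measured so far:
compound 1, `CSc1nc(Br)c(C(=O)c2ccccc2)s1`, in a functional assay on U-373MG ATCC cells (Homo sapiens) for cytotoxicity, read by MTT assay, with a stated time of 72 h; a lower number here means a stronger inhibitor, a higher number a weaker inhibitor: 89000 nM
compound 2, `O=C(c1ccccc1)c1sc(N2CCCC2)nc1Br`: > 100000 nM, which is a limit of the assay and not a number
compound 3, `COC(=O)c1sc2nc(SC)sc2c1C`: 92000 nM

Compound 1 and compound 2 differ by pyrrolidin-1-yl in place of methylsulfanyl on an aromatic carbon. That step is an at least 1.1-fold higher number from compound 1 to compound 2 (0.05 log units; that floor lies within the scatter), bounded by the limit of > 100000 nM in this assay, at which 1 of the 3 values shown sits. Compound 3 stands within the scatter of compound 1; how the two cores differ is not broken down here.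

Compound 4, `COC(=O)c1sc2nc(N3CCCC3)sc2c1C`, differs from compound 3 by pyrrolidin-1-yl in place of methylsulfanyl on an aromatic carbon. It is the same kind of change, not the same: here the ring is part of a fused or bridged system of two rings, whereas in compound 1 the ring carbon lay two ring bonds from the atom bearing bromo and from the atom bearing a group of 8 heavy atoms. Resting on the earlier step, compound 4 is expected to show a 1.4-fold higher number from compound 3 to compound 4 (0.15 log units; within the scatter). The estimated value of compound 4 is 130000 nM, between 60000 nM and 300000 nM.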

Compound 4, half-maximal inhibitory concentration: 89000 nM
Compound 4: the middle estimate sits 1.5-fold (0.16 log units) above what was measured; low and high end bracket the measured number.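

In this assay, pyrrolidin-1-yl in place of methylsulfanyl on an aromatic carbon gives a 1.0-fold lower number from compound 3 to compound 4 (0.01 log units; within the scatter). Set beside the earlier step, this shows no difference between the two cores, but it does not show that the change carries over unaltered: the same change on two cores in this assay, an at least 1.1-fold higher number (0.05 log units; that floor lies within the scatter) from compound 1 to compound 2 and a 1.0-fold lower number (0.01 log units; within the scatter) from compound 3 to compound 4; the limit leaves it open whether they differ. As far as these compounds go, compound 2 stands at a limit of the assay and not at a number, so the size of the step on the core of compound 1 stays unknown: the limit of > 100000 nM in this assay, at which 1 of the 4 values shown sits.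

The compounds shown leave open how other groups at this place, such as an open-chain amine or a carboxylic acid, would read in this assay. They also leave open whether the change would behave alike on any core beyond these two.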